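The compounds below may be only part of what the source reports. "The series", "measured", "known", "first", "only" and "open" are said of these compounds alone.

Among the compounds with values here, compound 2 `Cc1nc(N)c2c(-c3cc4ccccc4o3)cn([C@@H]3O[C@H](CO)[C@@H](O)[C@H]3O)c2n1` gives 6310 nM in a functional assay on CEM-DNR-bulk cells (Homo sapiens), read by MTT assay, with a stated time of 72 h (on this read-out lower numbers stand for stronger inhibition and higher numbers for weaker inhibition), the only true number so far. Compound 1 `Cc1nc(N)c2c(-c3cccs3)cn([C@@H]3O[C@H](CO)[C@@H](O)[C@H]3O)c2n1` reads > 20000 nM, which is a limit of this assay. Within the data shown here, the one measured step is an at least 3.1-fold lower number from compound 1 to compound 2 (0.50 log units; beyond the scatter). Only thin evidence frames it: the limit of > 20000 nM in this assay, at which 1 of the 2 values shown sits.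

Compound 3 `Cc1nc(N)c2c(I)cn([C@@H]3O[C@H](CO)[C@@H](O)[C@H]3O)c2n1` differs from compound 2 by iodo in place of 1-benzofuran-2-yl on an aromatic carbon. Among the measured compounds shown here, no measured step involves iodo, so the only guide is an at least 3.1-fold lower number from compound 1 to compound 2 (0.50 log units; beyond the scatter), which brought in the 1-benzofuran-2-yl group that compound 3 now lacks. On that basis, a modest rise in the number is expected, back towards the limit reached by compound 1, and a reading that is itself only a limit would be no surprise. The expected change is a 2.2-fold higher number from compound 2 to compound 3 (0.35 log units; beyond the scatter). For compound 3, the estimated value is 14000 nM, with an expected range of 4000 nM to 40000 nM.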

Compound 3, half-maximal inhibitory concentration: 3480 nM
Compound 3: the middle estimate sits 4.0-fold (0.60 log units) above what was measured, outside the stated range (below it).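

In this assay, iodo on this aromatic carbon of the shared core, two ring bonds from the ring nitrogen, does as well as the much larger 1-benzofuran-2-yl group: a 1.8-fold lower number from compound 2 to compound 3 (0.26 log units; within the scatter) is the step, so an aromatic ring at this place is not required for a reading in this range. Thiophen-2-yl is the group that stands apart, with an at least 5.7-fold lower number from compound 1 to compound 3 (0.75 log units; beyond the scatter) as the step when iodo replaces it. The true size of that step stays unknown, and it is only a bound for this reason: the limit of > 20000 nM in this assay, at which 1 of the 3 values shown sits.

The compounds shown leave open how a plain hydrogen, a methyl group or an amine would read at this place. They also do not tell why thiophen-2-yl parts from both 1-benzofuran-2-yl and iodo.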